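Three limits, and a sulfanyl change awaiting its number

The source may hold more compounds than are shown below. What is called first, only, known or untested is meant among the compounds shown, and "the series" means these compounds.

Compound 1 `COc1ccc(-c2nc(CNc3cccc(Cl)c3)nc3ccsc23)cn1` gives > 50000 nM in an ADME assay on cells (Homo sapiens) for cytotoxicity, read by resazurin assay, with a stated time of 5 days (on this read-out higher numbers stand for lower toxicity in this test and lower numbers for higher toxicity in this test), a limit of the test rather than a number.
Compound 2 `COc1ccc(-c2nc(COc3cccc(Cl)c3)nc3ccsc23)cn1` gives > 50000 nM in this assay, again a limit.
Compound 3 `COc1ccc(-c2nc(CCc3cccc(Cl)c3)nc3ccsc23)cn1` gives > 50000 nM in this assay, also a limit.

All three measured compounds share the same core and differ only in the group on a saturated chain carbon bound to an aromatic carbon. Within the data shown here, because every value sits at the same limit (the limit of > 50000 nM in this assay, at which 3 of the 3 values shown sit), none of the measured steps can be read: a step that the two limits leave unreadable from compound 1 to compound 2, a step that the two limits leave unreadable from compound 1 to compound 3, and a step that the two limits leave unreadable from compound 2 to compound 3. Compound 3 therefore stands at the limit, on equal footing with compound 1 and compound 2 as far as these numbers show.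

Compound 4 `COc1ccc(-c2nc(CSc3cc(Cl)ccc3Cl)nc3ccsc23)cn1` is not yet measured. It differs from compound 3 in one place: (2,5-dichlorophenyl)sulfanyl in place of 3-chlorobenzyl on a saturated chain carbon bound to an aromatic carbon. The three unreadable steps give no size or direction to carry forward, so no step beyond the scatter is expected in this assay; the expected step is a step that the limit leaves unreadable from compound 3 to compound 4. On that basis compound 4 is estimated at 60000 nM, with a range from 20000 nM to 200000 nM, and most likely it will again be reported only as a limit.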

Compound 4, half-maximal cytotoxic concentration: > 50000 nM
Compound 4: only a limit was reported (the forecaster's own chance of this, stated with the estimate: 80%); the middle value does not contradict the limit.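

In this assay compound 4 gives > 50000 nM as a limit of the test and not a number. No new step can be read between compound 4 and compound 1, compound 2 or compound 3, because all four values sit at one limit: the limit of > 50000 nM in this assay, at which 4 of the 4 values shown sit.

The compounds shown leave open how far the true values of these four compounds lie from that limit, and whether any of them differ at all.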